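This account rests on a few compounds, and the source may have more. Where it says the series, first, only, none or still open, it means among the compounds named here.

Compound 1 `O=C(CC1SCCNC1=O)Nc1ccccc1` gives 0.8
Compound 2 `COc1ccc(NC(=O)CC2SCCNC2=O)cc1F` gives 1.1
Compound 3 `CCOc1ccc(NC(=O)CC2SCCNC2=O)cc1` gives 1.3

These numbers come from a physicochemical assay for lipophilicity, using the shake flask method, measured as octanol-water partition, at pH 7.4 (on this read-out higher numbers stand for higher lipophilicity and lower numbers for lower lipophilicity), and the three compounds share one core. Compound 3 lies within the usual scatter of compound 2, and it is the only one of the three that stands clear of compound 1.

Compound 4 `O=C(CC1SCCNC1=O)Nc1ccc(O)cc1` has not yet been measured. It differs from compound 3 by hydrogen in place of ethyl on an oxygen on an aromatic ring (ethoxy to hydroxy, (hydrogen in place of ethyl on an oxygen on an aromatic ring)). Among the measured compounds shown here, the one measured step that bears on this change is ethoxy in place of hydrogen on an aromatic carbon, which gave a number 0.50 log units higher from compound 1 to compound 3 (beyond the scatter) as a modest shift. Compound 4 loses the same ethyl but keeps its oxygen, so it does not simply return to compound 1. For the measured compounds named here, no measured compound carries hydroxy, which leaves that part of the change without direct evidence. The estimated step is a number 0.90 log units lower from compound 3 to compound 4 (beyond the scatter) and so it is expected to run downward, somewhat past the size of the measured step. The estimate in this assay for compound 4 is 0.4 with an expected range (from 0 to 0.8).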

Compound 4, distribution coefficient: 0.1
The estimate for compound 4 lay 0.30 log units above the measured number, and the stated range covers the measured number.
By their numbers in this assay, from the lowest: compound 4; then compounds 1, 2 and 3 (each within the scatter of the next, the first and the last beyond it).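

In this assay, hydroxy in place of hydrogen on the aromatic carbon gave a number 0.70 log units lower from compound 1 to compound 4 (beyond the scatter) while ethoxy in place of the same hydrogen gave a number 0.50 log units higher from compound 1 to compound 3 (beyond the scatter) and so this place can move the number in either direction from compound 1. Hydrogen in place of ethyl on the oxygen gave a number 1.20 log units lower from compound 3 to compound 4 (beyond the scatter) as a large step, and the oxygen alone does not set the number here: compound 3 and compound 4 both carry it, yet they fall on opposite sides of compound 1. Nothing measured here accounts for the size of this step or for the change of direction.

As far as these compounds go, with only hydroxy and ethoxy compared on their own at this place, it remains open where an amine or a carboxylic acid on the same aromatic carbon would fall relative to compound 1. From the compounds shown here alone, it also remains open whether a longer chain on the oxygen, such as propoxy or butoxy, would carry the number further up from compound 3 or leave it within the usual scatter.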